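The source may report more compounds than this note shows. Statements on the series, on what has been measured and on what is new or still open speak of the compounds shown alone.

Measured in an in vitro ADME assay on microsomes from liver (Mus musculus) for pharmacokinetics; on this read-out higher numbers stand for fast clearance and lower numbers for slow clearance:
- Compound 1 `CC(C)(C)C1CCNC(=O)C(N(Cc2ccc(C(=O)NC3CC3)cc2)S(=O)(=O)c2ccc(Cl)cc2)C1`: 110 mL.min-1.g-1
- Compound 2 `COc1ccc(CN([C@@H]2CC(F)(F)CCNC2=O)S(=O)(=O)c2ccc(Cl)cc2)c(F)c1`: 105 mL.min-1.g-1

Compound 1, at 110 mL.min-1.g-1, has the highest number of the two, but compound 2, at 105 mL.min-1.g-1, lies within the scatter of it, so the two count as level. Compound 3 `O=C(NC1CC1)c1ccc(CN(C2CC(C(F)(F)F)CCNC2=O)S(=O)(=O)c2ccc(Cl)cc2)cc1` has trifluoromethyl in place of tert-butyl on a saturated ring carbon. Among the measured compounds shown here, no measured pair shows what this change does, so the expectation rests on the structures alone. In this assay the expected step is a 2.0-fold lower number from compound 1 to compound 3 (0.30 log units; within the scatter), an estimated move toward slower clearance, modestly beyond the scatter. The estimate for compound 3 is 55 mL.min-1.g-1, with an expected range of 25 mL.min-1.g-1 to 110 mL.min-1.g-1.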

Compound 3, intrinsic clearance in microsomes: 39 mL.min-1.g-1
For compound 3 the middle estimate is 1.4-fold (0.15 log units) above the measured one; the measured number falls inside the stated range.
By their numbers in this assay, from the lowest: compound 3; then compounds 2 and 1 (each within the scatter of the next).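

In this assay, trifluoromethyl in place of tert-butyl on this saturated ring carbon gives a 2.8-fold lower number from compound 1 to compound 3 (0.45 log units; beyond the scatter) and so shows that clearance responds to the group held at this position, with the rest of compound 1 unchanged. This rests on a single pair of compounds, and no measurement at hand accounts for the step. Going by these compounds, whether methyl, a hydroxyl or a nitrile on the same ring carbon would give a lower number stays open. So does whether this step would hold with a different group on the sulfonyl side.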